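A few compounds are considered here, and "the series" means these few. Any claim that something is new, unique, unknown or untested is made for them only; others in the source may bear on it.

Measured so far, cytotoxicity toward THP-1 cells:

compound 1 `O[C@@H]1Cc2cc(F)ccc2N[C@H](c2cccs2)C1` gives 190000 nM
compound 2 `Cc1ccc([C@@H]2C[C@H](O)Cc3cc(F)ccc3N2)s1` gives 312000 nM
compound 3 `O[C@@H]1Cc2ccccc2N[C@H](c2ccco2)C1` gives 236000 nM

In an ADME assay on THP-1 cells (Homo sapiens) for cytotoxicity (on this read-out higher numbers stand for lower toxicity in this test and lower numbers for higher toxicity in this test), the three measured compounds sit close together. Among the compounds with values here, the only counted step is a 1.6-fold higher number from compound 1 to compound 2 (0.22 log units; within the scatter), the change being (methyl in place of hydrogen on an aromatic carbon). Compound 3 stands apart from compound 1 and compound 2 in its core as well; the difference between the two cores is not broken down here, and the values of compound 3 and compound 1 in this assay lie within the scatter of each other.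

Compound 4 `Cc1ccc([C@@H]2C[C@H](O)Cc3ccccc3N2)o1` is not yet measured in this assay. It is reached from compound 3 by methyl in place of hydrogen on an aromatic carbon. Within the data shown here, this is the same kind of change as the one from compound 1 to compound 2, with one difference around the place: in compound 2 the entering methyl sits on a five-membered aromatic ring with one sulfur, next to the ring sulfur, whereas in compound 4 it sits on a five-membered aromatic ring with one oxygen, next to the ring oxygen.

Among the measured compounds shown here, for compound 4 the expected step in this assay is a 1.3-fold higher number from compound 3 to compound 4 (0.10 log units; within the scatter), a shift of about the same size as the measured one, because a 1.6-fold higher number from compound 1 to compound 2 (0.22 log units; within the scatter) fell within the scatter and nothing among the measured compounds points to a larger effect of the methyl. For the measured compounds named here, the value expected for compound 4 in this assay is therefore 300000 nM, with a range from 150000 nM to 600000 nM, and the estimate rests on only one measured example of this kind of change.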

Compound 4, half-maximal cytotoxic concentration: 262000 nM
Beside the measured number, compound 4's estimate is 1.1-fold (0.06 log units) above it, and the stated range covers the measured number.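

In this assay methyl in place of hydrogen on an aromatic carbon gives a 1.1-fold higher number from compound 3 to compound 4 (0.05 log units; within the scatter) on the core of compound 3, where furan-2-yl becomes 5-methylfuran-2-yl, and on neither core does the change move the number beyond the scatter. Within the data shown here, this does not show that the methyl has no effect at all, nor that any small effect is the same on both cores: only two pairs are available, neither step stands clear of the scatter, and steps of this size could hide a modest real shift. Set side by side, the two steps give no sign that the core alters the outcome of this change: the same change on two cores in this assay, a 1.6-fold higher number (0.22 log units; within the scatter) from compound 1 to compound 2 and a 1.1-fold higher number (0.05 log units; within the scatter) from compound 3 to compound 4, 1.5-fold (0.17 log units) apart, within the scatter of two such steps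

The compounds shown leave open whether anything other than methyl at this place, such as an amine, a carboxylic acid or a longer chain, would move the number beyond the scatter in this assay on either core. From the compounds shown here alone, compound 1 and compound 3 differ in more than one place, so what the fluorine on the core contributes by itself also stays open, as does the effect of exchanging the ring oxygen for sulfur.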